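Substituent on the chain carbon at the ring nitrogen

The source may hold more compounds than are shown below. What is called first, only, known or untested is meant among the compounds shown, and "the series" means these compounds.

Compound 1, `CCCc1nc(C)c2c(C)nn(C)c(=O)n12`: in a functional assay for inhibition, with Homo sapiens as the target (on this read-out higher numbers stand for weaker inhibition and lower numbers for stronger inhibition), compound 1 gives > 48000 nM, a limit of the assay.
Compound 2, `CCCc1nc(C)c2cnn(CC3CC3)c(=O)n12`: in this assay compound 2 gives > 48000 nM, a limit of the assay.
Compound 3, `CCCc1nc(C)c2cnn(C)c(=O)n12`: in this assay compound 3 gives 20000 nM.

Compound 3 carries the only number shown; the other two sit at the limit of > 48000 nM in this assay, at which 2 of the 3 values shown sit. The two measured steps, an at least 2.4-fold lower number from compound 1 to compound 3 (0.38 log units; beyond the scatter) and an at least 2.4-fold lower number from compound 2 to compound 3 (0.38 log units; beyond the scatter), both read from a limit to a number. Compound 4, `CCCc1nc(C)c2cnn(CC(O)CO)c(=O)n12`, differs from compound 3 by 1,2-dihydroxyethyl in place of hydrogen on a saturated chain carbon bound to an aromatic nitrogen. Among the measured compounds shown here, the one step at this place, from compound 2 to compound 3, came from a bulkier group to hydrogen and lowered the number; the reverse direction is therefore expected here, a rise of a 2.0-fold higher number from compound 3 to compound 4 (0.30 log units; within the scatter), possibly back to the limit. Compound 4 is estimated at 40000 nM, between 15000 nM and 110000 nM.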

Compound 4, half-maximal inhibitory concentration: > 48000 nM
Compound 4: a limit, no number; the forecaster's own chance of this, stated with the estimate: 55%; at least 1.2-fold (0.07 log units) between middle value and limit.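

Placing 1,2-dihydroxyethyl on the saturated chain carbon bound to an aromatic nitrogen gives an at least 2.4-fold higher number from compound 3 to compound 4 (0.38 log units; beyond the scatter) in this assay, so this hydroxylated, ring-free group is not tolerated any better than the cyclopropyl of compound 2. Compound 2 and compound 4 both end at a limit, and the step between them cannot be read. Most of the series now rests on one limit: the limit of > 48000 nM in this assay, at which 3 of the 4 values shown sit.

On these data alone, whether a small amine, a carboxylic acid or a longer alkyl chain at this place would hold the number of compound 3 stays open. Any ranking of compound 2 against compound 4 also stays open.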